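The source may report more compounds than this note shows. Statements on the series, on what has been measured and on what is new or still open speak of the compounds shown alone.

Measured in a functional assay on B16-F0 cells (Mus musculus) for inhibition, read by CCK-8 assay, with a stated time of 48 h (a lower number here means a stronger inhibitor, a higher number a weaker inhibitor), so far:

- Compound 1 (`COc1cc(-c2cc3nccc(-c4cc(OC)c(OC)c(OC)c4)n3n2)cc(OC)c1OC`) gives > 10000 nM as a limit
- Compound 2 (`COc1cc(-c2cc3nccc(-c4c[nH]c5ccccc45)n3n2)cc(OC)c1OC`) gives > 10000 nM as a limit
- Compound 3 (`COc1cc(-c2ccnc3cc(-c4ccccc4)nn23)cc(OC)c1OC`) gives 4730 nM as a number

Going by the values given here, compound 3 holds the only true number of the three. Its half-maximal inhibitory concentration of 4730 nM is therefore the one firm reference point here. Compound 1 and compound 2 each stop at a limit of the assay, so neither offers an exact figure to compare with.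

Compound 4 (`COc1cc(-c2ccnc3cc(-c4ccc(N(C)C)cc4)nn23)cc(OC)c1OC`) keeps the shared core of compound 3 and differs in one place (dimethylamino in place of hydrogen on an aromatic carbon). Phenyl becomes 4-(dimethylamino)phenyl, with dimethylamino in place of hydrogen on an aromatic carbon, para to a large group.

Among the compounds with values here, no two measured compounds differ in just one place, so the data give no direct guide to the size of this step, and any expectation must stay loose. A moderate gain is the working guess. In this assay the expected change (a 3.2-fold lower number from compound 3 to compound 4 (0.50 log units; beyond the scatter)) points toward a stronger inhibitor, somewhat beyond the usual scatter of repeat measurements. Compound 4 could still end up at a limit rather than a number. The estimated value for compound 4 is 1500 nM with an expected range from 150 nM to 10000 nM for now.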

Compound 4, half-maximal inhibitory concentration: 702 nM
Compound 4: middle estimate off by 2.1-fold (0.33 log units), on the high side; low and high end bracket the measured number.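

Putting dimethylamino in place of hydrogen on this aromatic carbon, para to a large group, gives a 6.7-fold lower number from compound 3 to compound 4 (0.83 log units; beyond the scatter) in this assay. This makes the phenyl group of compound 3 a place where a single added group can change the measured inhibition by more than the usual scatter of repeat measurements. Until this pair, no two compounds shown differed in just one place, so this step is the only direct measure of what one change does, and it shows a stronger inhibitor for this one group without showing why.

As far as these compounds go, whether this gain is specific to dimethylamino stays open, since a plain amino group, a longer diethylamino group or a carboxylic acid on the same carbon could give a very different number. Compound 1 and compound 2 add no further comparison, as neither differs from compound 4 in just one place and each stops at a limit rather than a number: the limit of > 10000 nM in this assay, at which 2 of the 4 values shown sit.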